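This account rests on a few compounds, and the source may have more. Where it says the series, first, only, none or still open, it means among the compounds named here.

Measured so far in a functional assay on SW-620 cells (Homo sapiens) for inhibition; on this read-out higher numbers stand for weaker inhibition and lower numbers for stronger inhibition:

Compound 1 `CC(C)C(NC(=O)NO)C(=O)NC1CCCCC1`: > 100000 nM
Compound 2 `CCC(C)C1NC(=O)N(C2CCCCC2)C1=O`: > 100000 nM
Compound 3 `CCC(C)C(NC(=O)NO)C(=O)NC1CCCCC1`: > 100000 nM

All three of these values are limits of the assay rather than numbers. For compound 1 the value > 100000 nM is a limit. For compound 2 the value > 100000 nM is likewise a limit. For compound 3 the value > 100000 nM is a limit as well, so that (the limit of > 100000 nM in this assay, at which 3 of the 3 values shown sit).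

Compound 3 and compound 1 differ by hydrogen in place of methyl on a saturated chain carbon, three bonds along the chain from an amide-type nitrogen and a carbonyl carbon. The step that the two limits leave unreadable from compound 3 to compound 1 cannot be read, since both ends sit at the limit. The difference between the core of compound 2 and the core of compound 3 is not broken down here.

Compound 4 `CC(C)C1NC(=O)N(C2CCCCC2)C1=O` has not yet been measured in this assay. It differs from compound 2 by hydrogen in place of methyl on a saturated chain carbon, two bonds along the chain from a saturated ring carbon. Among the compounds with values here, this is the same kind of change as the one from compound 3 to compound 1, but the place differs: in compound 2 the methyl sits two bonds along the chain from a saturated ring carbon, whereas in compound 3 it sits three bonds along the chain from an amide-type nitrogen and a carbonyl carbon.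

Because compound 2 gives only the limit > 100000 nM, and because compound 1 and compound 3 also sit at that limit, the expected step of a number no higher from compound 2 to compound 4 (the limit leaves the size open) is essentially none. Compound 4 is expected to give about 100000 nM, estimated between 30000 nM and 300000 nM, most likely reported again as a limit.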

Compound 4, half-maximal inhibitory concentration: > 100000 nM
Compound 4 was reported as a limit (the forecaster's own chance of this, stated with the estimate: 85%); the middle value lies on the limit itself.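

In this assay compound 4 gives > 100000 nM, which is a limit, so no step can be read from compound 2 to compound 4, as neither end is a number. The same holds across the whole set: the limit of > 100000 nM in this assay, at which 4 of the 4 values shown sit. The compounds shown leave open how strongly any of them inhibits, and whether hydrogen in place of methyl or the difference between the cores changes that at all.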